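The source may hold more compounds than are shown below. What is called first, only, known or untested is meant among the compounds shown, and "the series" means these compounds.

Compound 1 `CN(C)c1ccc(/C=C(/Sc2ccc(Br)cc2)C(=O)c2ccc(Cl)cc2)cc1`: > 100000 nM (a limit)
Compound 2 `Cc1ccc(/C=C(/SCc2ccc(F)cc2)C(=O)c2ccc(Cl)cc2)s1`: > 100000 nM (a limit)
Compound 3 `CN(C)c1ccc(/C=C(/SCc2ccc(Cl)cc2)C(=O)c2ccc(Cl)cc2)cc1`: > 100000 nM (a limit)

In a functional assay on DU-145 cells (Homo sapiens) for inhibition, read by trypan blue exclusion, with a stated time of 96 h (on this read-out lower numbers stand for stronger inhibition of growth and higher numbers for weaker inhibition of growth), compound 3 gives > 100000 nM as a limit and not a number, so it stands at the limit of > 100000 nM in this assay, at which 3 of the 3 values shown sit, with no readable rank. Compound 4 `CN(C)c1ccc(/C=C(/SCc2ccc(F)cc2)C(=O)c2ccc(Cl)cc2)cc1` puts fluoro in place of chloro on an aromatic carbon, para to a large group fluoro in place of chloro on an aromatic carbon in the change from compound 3. For the measured compounds named here, the one measured step nearby is a step that the two limits leave unreadable from compound 1 to compound 3 and it offers no size. Compound 2 carries 4-fluorobenzyl and gives > 100000 nM as a limit, so no step beyond the scatter is expected in this assay and no direction is foreseen. The estimated change is a number no higher from compound 3 to compound 4 (the limit leaves the size open) and no more. Compound 4 is expected at 100000 nM with an estimated range of 40000 nM to 150000 nM as its likely span.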

Compound 4, concentration for 50% growth inhibition: 50000 nM
Compound 4: the middle estimate sits 2.0-fold (0.30 log units) above what was measured, within the range that was stated.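

In this assay compound 4 alone among those shown gives a number, while the others stay at a limit: the limit of > 100000 nM in this assay, at which 3 of the 4 values shown sit. At this position, para to a large group, fluoro in place of chloro gives an at least 2.0-fold lower number from compound 3 to compound 4 (0.30 log units; that floor lies within the scatter). Two more steps end at the same compound, with 4-(dimethylamino)phenyl in place of 5-methylthiophen-2-yl giving an at least 2.0-fold lower number from compound 2 to compound 4 (0.30 log units; that floor lies within the scatter), and a different group on the sulfur giving an at least 2.0-fold lower number from compound 1 to compound 4 (0.30 log units; that floor lies within the scatter). On these data alone, the true size of each step stays open, since each starts from a limit. As far as these compounds go, whether a methoxy group or an amine at this position would shift the number also remains open.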